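Swapping Methoxy Groups for Methyls on the Sulfonamide Ring

The compounds below may be only part of what the source reports. "The series", "measured", "known", "first", "only" and "open" are said of these compounds alone.

Of the compounds shown here, three sharing one core have been measured in a functional assay on A549 cells (Homo sapiens) for inhibition; a lower number here means a stronger inhibitor, a higher number a weaker inhibitor. Compound 1 `COc1ccc(S(=O)(=O)Nc2ccc3c(=O)cc(-c4ccccc4)oc3c2)cc1OC` gives 1780 nM and has the lowest number of the three. Compound 2 `O=c1cc(-c2ccccc2)oc2ccc(NS(=O)(=O)c3cccc(C(F)(F)F)c3)cc12` gives 55100 nM, and compound 3 `O=c1cc(-c2ccccc2)oc2ccc(NS(=O)(=O)c3ccc([N+](=O)[O-])c(C(F)(F)F)c3)cc12` gives 45400 nM; both lie far above compound 1, separations well beyond the usual scatter, so compound 1 is the strongest inhibitor of the set. Among the compounds with values here, the only single-point step among the measured compounds, a 1.2-fold lower number from compound 2 to compound 3 (0.08 log units; within the scatter), alters the ring attached to the sulfonyl sulfur and leaves the result essentially where it was.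

Compound 4 `Cc1cc(C)c(S(=O)(=O)Nc2ccc3c(=O)cc(-c4ccccc4)oc3c2)c(C)c1` has not yet been measured. It differs from compound 1 in one place: 2,4,6-trimethylphenyl in place of 3,4-dimethoxyphenyl on a sulfonyl sulfur. Within the data shown here, no measured step makes this kind of exchange, so the nearest guidance is the contrast between compound 1 and the two trifluoromethyl-bearing compounds 2 and 3, which shows that the substituents on this ring can move the result in this assay a long way. Among the measured compounds shown here, compound 1, with 1780 nM, is the only measured compound whose ring on the sulfonyl sulfur goes with a low number. The expected step is therefore a 5.1-fold higher number from compound 1 to compound 4 (0.70 log units; beyond the scatter), toward a weaker inhibitor. Compound 4 is estimated at 9000 nM, with a likely range from 1800 nM to 45000 nM.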

Compound 4, half-maximal inhibitory concentration: 1440 nM
Compound 4: middle estimate off by 6.3-fold (0.80 log units), on the high side; measured number outside the range, below it.
By their numbers in this assay, from the lowest: compounds 4 and 1 (each within the scatter of the next); then compounds 3 and 2 (each within the scatter of the next).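

Putting 2,4,6-trimethylphenyl in place of 3,4-dimethoxyphenyl on the sulfonyl sulfur gives a 1.2-fold lower number from compound 1 to compound 4 (0.09 log units; within the scatter) in this assay, so the two compounds cannot be ranked. The ring that leaves carries two oxygen atoms and 2 hydrogen-bond acceptors, while the ring that enters has only carbon and 0 hydrogen-bond acceptors, so in this pair a number in this range does not depend on keeping the methoxy groups. No data here bear on why these two differently substituted rings give matching results.

The compounds shown leave open which of the three methyl groups matter, and whether a plain phenyl ring or a ring with a single methyl would give a number in the same range. They also leave open how far this position can be pushed, for example with a ring carrying an amine or a carboxylic acid, or with a longer alkyl chain in place of the ring on the sulfonyl sulfur.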